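A (tert-Butyl)sulfanyl Group in Place of Chloro

A few compounds are considered here, and "the series" means these few. Any claim that something is new, unique, unknown or untested is made for them only; others in the source may bear on it.

This account follows a single change on the shared core of compound 1 `Cc1cc(Cl)c(S(C)(=O)=O)cc1C(=O)N=C(N)N`, a guanidine-bearing benzamide that in a functional assay for inhibition of sodium/hydrogen exchanger (Oryctolagus cuniculus) (a higher number here means a weaker inhibitor, a lower number a stronger inhibitor), gives 25 nM. Among the three compounds measured so far, compound 1 stands second highest; compound 3 `Cc1cc(-c2ccc(Cl)cc2)c(S(C)(=O)=O)cc1C(=O)N=C(N)N`, which carries a 4-chlorophenyl group, gives 45 nM, and the step of a 1.8-fold higher number from compound 1 to compound 3 (0.26 log units; within the scatter) lies within the scatter. Compound 2 `Cc1cc(Br)c(S(C)(=O)=O)cc1C(=O)N=C(N)N`, with bromo at the same position, gives 12 nM, and the step of a 2.1-fold lower number from compound 1 to compound 2 (0.32 log units; beyond the scatter) lies beyond the scatter.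

The new compound 4 `Cc1cc(SC(C)(C)C)c(S(C)(=O)=O)cc1C(=O)N=C(N)N` differs from compound 1 in one place: (tert-butyl)sulfanyl in place of chloro on an aromatic carbon. Among the compounds with values here, the steps that bear on this change are those that swap the same chloro for another group. Bromo gave a 2.1-fold lower number from compound 1 to compound 2 (0.32 log units; beyond the scatter), while the much larger 4-chlorophenyl gave a 1.8-fold higher number from compound 1 to compound 3 (0.26 log units; within the scatter), and from compound 2 the aryl group gave a 3.8-fold higher number from compound 2 to compound 3 (0.57 log units; beyond the scatter). Taken together these steps suggest that a group with more heavy atoms at this position does not move the number far from compound 1, with the only clear gain seen for compound 2.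

Compound 4 is therefore expected to sit close to compound 1, with a 1.2-fold higher number from compound 1 to compound 4 (0.08 log units; within the scatter) as the estimated step. The estimated value for compound 4 is 30 nM, in a range from 10 nM to 90 nM.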

Compound 4, half-maximal inhibitory concentration: 22 nM
The estimate for compound 4 lay 1.4-fold (0.13 log units) above the measured number; the measured number falls inside the stated range.
By their numbers in this assay, from the lowest: compounds 2, 4, 1 and 3 (each within the scatter of the next, the first and the last beyond it).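

In this assay, replacing chloro (1 heavy atom) with the (tert-butyl)sulfanyl group (5 heavy atoms, no ring) leaves the number within the scatter (with a 1.1-fold lower number from compound 1 to compound 4 (0.06 log units; within the scatter)), so this position accepts a branched group that is attached through sulfur. The new group is also not separated from bromo (with a 1.8-fold higher number from compound 2 to compound 4 (0.26 log units; within the scatter)), but it does stand apart from the 4-chlorophenyl group (with a 2.0-fold lower number from compound 3 to compound 4 (0.31 log units; beyond the scatter)), a modest step beyond the scatter. Until now, only bromo had been separated from the 4-chlorophenyl group, whereas compound 4 gives a second such contrast, although compound 1 itself remains within the scatter of compound 3; no measurement shown here gives a reason for any of these steps.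

The compounds shown leave open whether the sulfur atom matters, since a plain tert-butyl group and a methylsulfanyl group would separate the linking atom from the branching. They also leave open how this position responds to an amine, a carboxylic acid or a longer alkyl chain.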